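The compounds below may be only part of what the source reports. "The series", "measured", "known", "first", "only" and "open" are said of these compounds alone.

In a functional assay on NCI-H460 cells (Homo sapiens) for inhibition, read by MTT assay, with a stated time of 24 h, tested at 0.1 ug/mL (a lower number here means less inhibition of growth, a higher number more inhibition of growth at the concentration tested), compound 1 (`O=C(CCCCC1CCSS1)Nc1ccccc1Cl`) gives 8%. For the measured compounds named here, only one other compound in this small set has a number: compound 3 (`O=C(CCCCC1CCSS1)Nc1ccc(OC(F)(F)F)cc1`) gives 7.05%, which lies within the usual scatter of the value for compound 1. The two therefore cannot be told apart in this assay. The third measured compound, compound 2 (`O=C(CCCCC1CCSS1)Nc1cccc(C(F)(F)F)c1`), is reported only as "not active" (no number reported), with no number attached.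

The next compound to be tested, compound 4 (`O=C(CCCCC(S)CCS)Nc1ccccc1Cl`), differs from compound 1 in one place: a group of 5 heavy atoms (3 carbon, 2 sulfur; no ring) in place of a group of 5 heavy atoms (3 carbon, 2 sulfur; one five-membered non-aromatic ring with 2 hetero atoms), on a saturated chain carbon, four bonds along the chain from a carbonyl carbon. The group that leaves has one five-membered non-aromatic ring with 2 hetero atoms, while the 1,3-disulfanylpropyl group that enters has no ring and 2 hydrogen-bond donors.

Going by the values given here, no measured pair in the set shows this change, so the data give no direct guide to its effect. The only anchor is the small number for compound 1, 8%. A step beyond the usual scatter is not expected, although a slight rise in growth inhibition is possible. The expected step, a number 2 percentage points higher from compound 1 to compound 4 (within the scatter), is therefore only an estimate. For compound 4, the estimated value is 10%, with an expected range from 2% to 24%.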

Compound 4, percent growth inhibition at one concentration: 6.36%
For compound 4 the middle estimate is 3.6 percentage points above the measured one; the range from low to high includes it.
By their numbers in this assay, from the lowest: compounds 4, 3 and 1 (each within the scatter of the next).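

Replacing the ring of compound 1 with the open 1,3-disulfanylpropyl group of compound 4, on a saturated chain carbon, four bonds along the chain from a carbonyl carbon, gives in this assay a number 1.6 percentage points lower from compound 1 to compound 4 (within the scatter). For the compounds shown here, this is the first step in the set at this place, as the earlier compounds differ from one another only on the other side of the amide. It shows that, at this single tested concentration, the closed five-membered ring with its 2 sulfur and the open group with 2 hydrogen-bond donors cannot be told apart, and that both compounds stay at a small growth inhibition. Nothing available here accounts for this result.

Going by these compounds, whether a carboxylic acid at this place on the chain, or a longer chain carrying the same open group, would produce a step beyond the scatter remains open. On these data alone, it is also open whether the open group would read the same way with the trifluoromethyl group of compound 2 or the trifluoromethoxy group of compound 3 on the other side of the amide.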